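Adding a Single Fluorine to a Pyridine Ring

This account rests on a few compounds, and the source may have more. Where it says the series, first, only, none or still open, it means among the compounds named here.

Measured so far:
- Compound 1, `Fc1ccc(NCc2ccc(CNc3ccc(F)cn3)cc2)nc1`: 68%
- Compound 2, `c1ccc(NCc2ccc(CNc3ncccn3)cc2)nc1`: 64%

Both compounds were tested in a functional assay on MDA-MB-231 cells for antagonist activity at C-X-C chemokine receptor type 4 (Homo sapiens), tested at 100 nM; a higher number here means a stronger effect of the compound at the concentration tested, a lower number a weaker effect. Compound 1 gives 68% and compound 2 gives 64%. Compound 2 holds the lowest of the two numbers, yet the gap to its nearest neighbour, compound 1, lies within the usual scatter, so the two cannot be told apart.

Compound 3, `Fc1ccc(NCc2ccc(CNc3ncccn3)cc2)nc1`, has not yet been measured in this assay. It differs from compound 2 in one place: fluoro in place of hydrogen on an aromatic carbon. The fluoro sits on an aromatic carbon of a six-membered aromatic ring with 1 nitrogen, two atoms from the ring nitrogen; seen one bond further out, pyridin-2-yl becomes 5-fluoropyridin-2-yl. Among the compounds with values here, no measured pair shows this change alone, so no step can be read off. Since compound 1, which carries fluoro on both outer rings, and compound 2, which carries none, give numbers within the scatter of each other, the expected step of a number 2 percentage points higher from compound 2 to compound 3 (within the scatter) is none beyond the scatter. Compound 3 is therefore estimated at 66%, with a range from 52% to 80%.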

Compound 3, a percentage reported as inhibition, at one concentration (the size of the read-out at that concentration, not a potency): 78%
Estimate against measurement, compound 3: 12 percentage points below, within the range that was stated.
By their numbers in this assay, from the lowest: compounds 2, 1 and 3 (each within the scatter of the next, the first and the last beyond it).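

In this assay, putting fluoro in place of hydrogen, which turns pyridin-2-yl into 5-fluoropyridin-2-yl, gives a number 14 percentage points higher from compound 2 to compound 3 (beyond the scatter) and so shows that this single atom can make a readable difference at this position. Changing the other outer group, pyrimidin-2-yl in place of 5-fluoropyridin-2-yl on an amine nitrogen, gives a number 10 percentage points higher from compound 1 to compound 3 (within the scatter) and leaves those two compounds indistinguishable. Nothing available here explains why the fluoro has this effect.

As far as these compounds go, it remains open whether the effect is specific to fluoro, or whether chloro, methyl or methoxy at the same position would do the same. From the compounds shown here alone, because the read-out comes from a single concentration, it also remains open how far compound 2 and compound 3 differ in potency.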